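Replacing bromo with acetamido: what to expect for compound 3

The compounds below may be only part of what the source reports. "The series", "measured", "known", "first", "only" and "open" are said of these compounds alone.

- Compound 1 `Cc1ccc(S(=O)(=O)N2C/C(=C\c3ccncc3)C(=O)/C(=C/c3ccccc3F)C2)cc1` gives > 20000 nM, a limit of the assay
- Compound 2 `O=C1/C(=C/c2ccncc2)CN(S(=O)(=O)c2ccc(Br)cc2)C/C1=C\c1ccccc1F` gives 19400 nM

For the measured compounds named here, in an ADME assay on L02 cells (Homo sapiens) for cytotoxicity, read by MTT assay, with a stated time of 24 h (on this read-out higher numbers stand for weaker inhibition and lower numbers for stronger inhibition), compound 2 gives 19400 nM, the only actual number so far. The result for compound 1 is just a limit. The next compound to be tested is compound 3 `CC(=O)Nc1ccc(S(=O)(=O)N2C/C(=C\c3ccncc3)C(=O)/C(=C/c3ccccc3F)C2)cc1`, which differs from compound 2 by acetamido in place of bromo on an aromatic carbon, with acetamido in place of bromo on an aromatic carbon, para to a large group. Going by the values given here, because an at least 1.0-fold lower number from compound 1 to compound 2 (0.01 log units; that floor lies within the scatter) is the only measured step at this aromatic carbon, with bromo in place of methyl, there is little to go on. That step gives no reason to expect a change beyond the scatter, and it sets no direction for the new group. The step expected in this assay is therefore a 1.0-fold higher number from compound 2 to compound 3 (0.01 log units; within the scatter), which means none beyond the scatter. Compound 3 may also report only a limit. Compound 3 is estimated at 20000 nM, with an expected range from 10000 nM to 40000 nM.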

Compound 3, half-maximal inhibitory concentration: 12300 nM
For compound 3 the middle estimate is 1.6-fold (0.21 log units) above the measured one; measured number inside the range.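

In this assay, the change from 4-bromophenyl to 4-acetamidophenyl gives a 1.6-fold lower number from compound 2 to compound 3 (0.20 log units; within the scatter). This position, on an aromatic carbon para to a large group, therefore accepts acetamido, with 4 heavy atoms, 1 hydrogen-bond donor and 1 hydrogen-bond acceptor, in place of a single bromine without a shift beyond the scatter, and it now has a step between two actual numbers rather than a floor alone. Against methyl the change reads an at least 1.6-fold lower number from compound 1 to compound 3 (0.21 log units; that floor lies within the scatter), and this can be stated only as a floor because compound 1 gives a limit rather than a number: the limit of > 20000 nM in this assay, at which 1 of the 3 values shown sits.

What the compounds shown leave open is whether any group on this aromatic carbon can move the number beyond the scatter, for example an amine, a carboxylic acid or a longer acyl chain on the amide nitrogen. They also leave open whether acetamido would read the same way if other parts of the shared core were changed, as all three compounds differ only at this one carbon.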